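The source may hold more compounds than are shown below. What is called first, only, known or untested is meant among the compounds shown, and "the series" means these compounds.

Of the compounds shown here, three built on a shared core have been measured in a functional assay on KYSE-450 cells (Homo sapiens) for inhibition, read by CCK-8 assay, with a stated time of 48 h; a lower number here means a stronger inhibitor, a higher number a weaker inhibitor. Compound 1 `COc1ccc(CN(C(=O)CSC(=S)N2CCN(C)CC2)c2cc(OC)c(OC)c(OC)c2)cc1` gives 1250 nM. Compound 2 `COc1ccc(CN(C(=O)CSC(=S)N2CCN(C(=O)OC(C)(C)C)CC2)c2cc(OC)c(OC)c(OC)c2)cc1` gives 250 nM, and compound 3 `COc1ccc(CN(C(=O)CSC(=S)N2CCN(Cc3ccc(C(C)(C)C)cc3)CC2)c2cc(OC)c(OC)c(OC)c2)cc1` gives 2140 nM. Compound 2 therefore stands lowest of the three: there is a 5.0-fold lower number from compound 1 to compound 2 (0.70 log units; beyond the scatter), and an 8.6-fold higher number from compound 2 to compound 3 (0.93 log units; beyond the scatter), while a 1.7-fold higher number from compound 1 to compound 3 (0.23 log units; within the scatter).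

Compound 4 `COc1ccc(CN(C(=O)CSC(=S)N2CCN(C(=O)OC(C)(C)C)CC2)c2cc(OC)c(OC)c(OC)c2)cc1N` is the next compound, not yet measured. It differs from compound 2 in one place: amino in place of hydrogen on an aromatic carbon, so that the 4-methoxybenzyl group becomes a 3-amino-4-methoxybenzyl group. Among the measured compounds shown here, every measured step so far concerns the group on the amine nitrogen in the ring, and none of them touches the aromatic ring that is changed here. The measured steps, at their largest, were modest. For the measured compounds named here, with no step that speaks to this change, no change beyond the usual scatter is expected in this assay, and compound 2 serves as the anchor.

Compound 4 is therefore expected to give about 280 nM, within a range from 90 nM to 900 nM, which means an expected step of a 1.1-fold higher number from compound 2 to compound 4 (0.05 log units; within the scatter).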

Compound 4, half-maximal inhibitory concentration: 208 nM
For compound 4 the middle estimate is 1.3-fold (0.13 log units) above the measured one; the measured number falls inside the stated range.
By their numbers in this assay, from the lowest: compounds 4 and 2 (each within the scatter of the next); then compounds 1 and 3 (each within the scatter of the next).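

Among the compounds shown here, this is the first change on the 4-methoxybenzyl group rather than on the amine nitrogen in the ring. In this assay, adding an amino group on the aromatic carbon ortho to the methoxy group gives a 1.2-fold lower number from compound 2 to compound 4 (0.08 log units; within the scatter), so in this one pair the new group leaves the number where it was, whereas some of the earlier changes on the ring nitrogen moved it beyond the scatter. Nothing available explains why this amino group makes no measurable difference.

On these data alone, it remains open whether a hydroxyl, a fluorine or an acetamide on the same carbon would also leave the number unchanged. Also open, as far as these compounds go, is whether the amino group would do the same with methyl or 4-(tert-butyl)benzyl on the ring nitrogen, as in compound 1 and compound 3, rather than tert-butoxycarbonyl.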